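Changing the anilino arm of compound 1

The source may report more compounds than this note shows. Statements on the series, on what has been measured and on what is new or still open speak of the compounds shown alone.

Compound 1 `C=CC(=O)Nc1cc(Nc2ncc(Cl)c(Nc3ccccc3S(=O)(=O)C(C)C)n2)c(OC)cc1N1CCN(C)CC1` was tested in a functional assay on NCI-H3122 cells (Homo sapiens) for inhibition, read by CellTiter-Glo, with a stated time of 72 h (a lower number here means a stronger inhibitor of growth, a higher number a weaker inhibitor of growth), and gives 33 nM, the highest of the two plain numbers in this set. Its closest neighbour is compound 3 `C=CC(=O)Nc1cc(Nc2ncc(Cl)c(Nc3ccccc3S(=O)(=O)C(C)C)n2)c(OC)cc1N1CCCCC1`, which in this assay gives 29 nM; the step of a 1.1-fold lower number from compound 1 to compound 3 (0.06 log units; within the scatter) shows that the two sit together. Compound 2 `C=CC(=O)Nc1cc(Nc2ncc(Cl)c(Nc3ccccc3S(=O)(=O)C(C)C)n2)c(OC)cc1N1CCN(C2CCCCC2)CC1` is reported in this assay only as a limit, < 0.3 nM. That limit is the limit of < 0.3 nM in this assay, at which 1 of the 3 values shown sits. The step of an at least 110-fold lower number from compound 1 to compound 2 (2.04 log units; beyond the scatter) is therefore large, as is the step of an at least 96-fold higher number from compound 2 to compound 3 (1.98 log units; beyond the scatter).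

Compound 4 `C=CC(=O)Nc1cc(Nc2ncc(Cl)c(Nc3cccc(C(F)(F)F)c3)n2)c(OC)cc1N1CCN(C)CC1` differs from compound 1 in one place: 3-(trifluoromethyl)phenyl in place of 2-(isopropylsulfonyl)phenyl on a nitrogen on an aromatic ring. Among the measured compounds shown here, none of the measured steps touches this part of the shared core; the steps from compound 1 to compound 2 and from compound 1 to compound 3 concern only the amine ring on the other side of the molecule. The measured data thus give no direct guide to the size or direction of the step in this assay for this change. Compound 4 is expected to give an estimate of 150 nM, with a range from 20 nM to 1500 nM, and the expected step is a 4.5-fold higher number from compound 1 to compound 4 (0.66 log units; beyond the scatter), a wide range that reflects the absence of any measured comparison for this change.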

Compound 4, concentration for 50% growth inhibition: 770 nM
Compound 4: middle estimate off by 5.1-fold (0.71 log units), on the low side; the range from low to high includes it.
By their numbers in this assay, from the lowest: compounds 3 and 1 (each within the scatter of the next); then compound 4. At a limit, below all of these: compound 2.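

The anilino arm now has a measured step of its own: in this assay, 3-(trifluoromethyl)phenyl in place of 2-(isopropylsulfonyl)phenyl gives a 23-fold higher number from compound 1 to compound 4 (1.37 log units; beyond the scatter) and so shows that this position is not indifferent to change. The earlier steps shown here touched only the amine ring, where a 1.1-fold lower number from compound 1 to compound 3 (0.06 log units; within the scatter) left the number in place and an at least 110-fold lower number from compound 1 to compound 2 (2.04 log units; beyond the scatter) moved it the other way, so the anilino arm is a second place in these compounds where one change alone moves the number beyond the scatter. The evidence at hand concerns only the limit reported for compound 2 and offers no explanation for this new step.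

Going by these compounds, the change alters two things at once, the substituent and where its name places it on the phenyl ring, so it remains open whether a 3-(isopropylsulfonyl)phenyl or a 2-(trifluoromethyl)phenyl group would behave like compound 1 or like compound 4. Also open, on these data alone, are whether a smaller sulfone such as methylsulfonyl would serve in place of isopropylsulfonyl, and whether the cyclohexyl group on the piperazine would have the same effect with 3-(trifluoromethyl)phenyl in the anilino arm.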